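A few compounds are considered here, and "the series" means these few. Any claim that something is new, unique, unknown or untested is made for them only; others in the source may bear on it.

Working notes on the series. Compound 1 `Oc1ccc(CN(Cc2ccccc2C(F)(F)F)Cc2ccc(O)c3ncccc23)c2cccnc12` is the reference point of the pair measured so far. In a functional assay on U-87MG ATCC cells (Homo sapiens) for antiproliferative activity, with a stated time of 3 days (a lower number here means that less compound is needed, a higher number that more compound is needed for the effect), compound 1 gives < 0.2 uM, which is a limit of the assay rather than a number. Compound 2 `Oc1ccc(CN(Cc2cc(C(F)(F)F)cc(C(F)(F)F)c2)Cc2ccc(O)c3ncccc23)c2cccnc12` carries a different arm on the shared core. In this assay compound 2 gives < 0.2 uM, again only a limit. Going by the values given here, both values therefore sit at the limit of < 0.2 uM in this assay, at which 2 of the 2 values shown sit, so compound 1 stands at the limit alongside the one other measured compound, and no order between the two can be read.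

Compound 3 `Oc1ccc(CN(Cc2cccc(I)c2)Cc2ccc(O)c3ncccc23)c2cccnc12` is the next point, differing from compound 1 by 3-iodophenyl in place of 2-(trifluoromethyl)phenyl on a saturated chain carbon bound to an amine nitrogen. Among the compounds with values here, no step between measured compounds is available. Compound 2, at < 0.2 uM, stayed at the limit after its own aryl change, so the expected step that the limit leaves unreadable from compound 1 to compound 3 is none beyond the scatter. For compound 3 the estimated value in this assay is 0.1 uM, with a range of 0.02 uM to 0.5 uM.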

Compound 3, concentration for half-maximal effect: 2 uM
Estimate against measurement, compound 3: 20-fold (1.30 log units) below; the whole stated range lies below it.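

In this assay the change from 2-(trifluoromethyl)phenyl to 3-iodophenyl on a saturated chain carbon bound to an amine nitrogen gives an at least 10-fold higher number from compound 1 to compound 3 (1.00 log units; beyond the scatter), so the response at this position depends on which aryl group it carries. Going by these compounds alone, compound 3 is the first compound with a value that is a number and not a limit, which gives the series its first readable step. The size of that step is only a lower bound, since compound 1 stands at a limit: the limit of < 0.2 uM in this assay, at which 2 of the 3 values shown sit.

The step changes the substituent, from trifluoromethyl to iodine, together with its printed ring position, and the compounds shown do not separate these two parts of the change. As far as these compounds go, how a 2-iodophenyl arm, a 3-(trifluoromethyl)phenyl arm or a phenyl arm carrying a carboxylic acid would read in this assay remains open.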